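This account rests on a few compounds, and the source may have more. Where it says the series, first, only, none or still open, it means among the compounds named here.

Measured in an assay on isolated protein for displacement of a labelled ligand from metabotropic glutamate receptor 5 (Homo sapiens), with a stated time of 60 min, tested at 1 uM; on this read-out lower numbers stand for less inhibition and higher numbers for more inhibition at the one concentration tested (going by the name of the read-out):

Compound 1 `CC1CCN(c2c(S(=O)(=O)c3ccc(Cl)c(Cl)c3)cnc3ccc(Cl)cc23)CC1`: 86%
Compound 2 `CC1CCN(c2c(S(=O)(=O)c3ccc(Cl)c(Cl)c3)cnc3c(F)cccc23)CC1`: 95%
Compound 3 `CC1CCN(c2c(S(=O)(=O)c3ccc(F)c(F)c3)cnc3ccc(Cl)cc23)CC1`: 72%

Compound 1 and compound 2 share a sulfonyl-linked 3,4-dichlorophenyl group, but the difference between their two cores is not broken down here. Compound 3 carries the core of compound 1 with 3,4-difluorophenyl in place of 3,4-dichlorophenyl on a sulfonyl sulfur, and in this assay the change gives a number 14 percentage points lower from compound 1 to compound 3 (beyond the scatter). Compound 4 `CC1CCN(c2c(S(=O)(=O)c3ccc(F)c(F)c3)cnc3c(F)cccc23)CC1`, not yet measured, makes the same change on the core of compound 2, namely (3,4-difluorophenyl in place of 3,4-dichlorophenyl on a sulfonyl sulfur). For the measured compounds named here, the step from compound 1 to compound 3 is the only measured example of this change, so the expectation for compound 4 rests on it alone and on compound 2 at 95%. A step of about a number 14 percentage points lower from compound 2 to compound 4 (beyond the scatter) is expected from compound 2 to compound 4 in this assay because the earlier change gave a number 14 percentage points lower from compound 1 to compound 3 (beyond the scatter). Compound 4 is therefore estimated at 81%, likely between 68% and 92%.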

Compound 4, a percentage reported as inhibition, at one concentration (the size of the read-out at that concentration, not a potency): 93%
Compound 4: the middle estimate sits 12 percentage points below what was measured; the measured number lies above the stated range.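

In this assay, putting 3,4-difluorophenyl in place of 3,4-dichlorophenyl on a sulfonyl sulfur gives a number 2 percentage points lower from compound 2 to compound 4 (within the scatter) on this second core. Set beside the earlier step, the result gives no firm sign that the change behaves differently on the two cores: the same change on two cores in this assay, a number 14 percentage points lower (beyond the scatter) from compound 1 to compound 3 and a number 2 percentage points lower (within the scatter) from compound 2 to compound 4, 12 percentage points apart, within the scatter of two such steps. For the compounds shown here, this rests on only two pairs of compounds, so it does not show that the steps are equal or that the change would carry the same way to any other core, and readings at one concentration do not show whether potency is kept.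

The compounds shown leave open how other groups on the sulfonyl sulfur would fare, such as an unsubstituted phenyl, a pyridine or a simple methyl. They also leave open whether an amine or a carboxylic acid on that aromatic ring would give a higher, lower or level number in this assay.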